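The source may hold more compounds than are shown below. What is called first, only, known or untested is meant among the compounds shown, and "the series" means these compounds.

Of the compounds shown here, three built on a shared core have been measured in an assay on HEK293 cells for inhibition of Voltage-dependent T-type calcium channel subunit alpha-1G (Homo sapiens), tested at 10 uM; a higher number here means more inhibition at the concentration tested (going by the name of the read-out), a lower number less inhibition. Compound 1 `CC(C)(C)OC(=O)NCCCCCN1C(Nc2ccc(-c3ccccc3)cc2)=Nc2ccccc2C1CC(=O)NCc1ccccc1` gives 88.5% in this assay. Compound 2 `COC(=O)CC1c2ccccc2N=C(NCCCCCNC(=O)OC(C)(C)C)N1c1ccc(-c2ccccc2)cc1` gives 86.5% in this assay, and compound 3 `COC(=O)CC1c2ccccc2N=C(Nc2ccc(-c3ccccc3)cc2)N1CCCCCNC(=O)OC(C)(C)C` gives 88.5% in this assay. Compound 2 holds the lowest of the three numbers, yet its gap to compound 1 and its gap to compound 3 both lie within the scatter, so the three values cannot be set in any order. Compound 1 and compound 3 differ in one place, (benzylamino in place of methoxy on a carbonyl carbon), and the step of no change at the digits printed from compound 3 to compound 1 (within the scatter) is unchanged at the digits reported. Compound 2 and compound 3 are made of the same atoms joined differently; the difference between the two cores is not broken down here.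

Compound 4 `CC(C)(C)OC(=O)NCCCCCNC1=Nc2ccccc2C(CC(=O)NCc2ccccc2)N1c1ccc(-c2ccccc2)cc1` has not yet been measured in this assay. Among the measured compounds shown here, it differs from compound 2 by benzylamino in place of methoxy on a carbonyl carbon, which is the same change, at the same place, as the one from compound 3 to compound 1. The expectation for compound 4 rests on compound 2 at 86.5% and on the earlier step, because no change at the digits printed from compound 3 to compound 1 (within the scatter) left the read-out where it was. The step of a number 0.5 percentage points higher from compound 2 to compound 4 (within the scatter) is therefore expected to be of about the same small size. Compound 4 is accordingly estimated to give 87% in this assay, with a range from 77% to 95%.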

Compound 4, a percentage reported as inhibition, at one concentration (the size of the read-out at that concentration, not a potency): 88.3%
Estimate against measurement, compound 4: 1.3 percentage points below, and the stated range covers the measured number.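

In this assay, putting benzylamino in place of methoxy on a carbonyl carbon gives a number 1.8 percentage points higher from compound 2 to compound 4 (within the scatter). Set beside the same change on the other core, the two steps do not differ, and both remain small: the same change on two cores in this assay, no change at the digits printed (within the scatter) from compound 3 to compound 1 and a number 1.8 percentage points higher (within the scatter) from compound 2 to compound 4, 1.8 percentage points apart, within the scatter of two such steps. So, on the two cores shown, the change can be carried from one to the other without a step that stands out from the scatter, but this does not show a general rule for the series, and the read-out gives only the size of the effect at one concentration, so it does not show how these compounds would compare at any other concentration.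

The compounds shown leave open how the read-out would respond to other groups on that carbonyl carbon, such as a hydroxyl that would make a carboxylic acid, or to a free amine in place of the carbamate. They also leave open what a longer chain would do, and whether the benzylamino change would stay this small on a core that gives a much lower number in this read-out.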